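A Methylphenoxy Tail in Place of a Phenyl Tail

A few compounds are considered here, and "the series" means these few. Any claim that something is new, unique, unknown or untested is made for them only; others in the source may bear on it.

Of the compounds shown here, three sharing a bicyclic amide core have been measured in an assay for inhibition of acyl-CoA:cholesterol acyltransferase (Oryctolagus cuniculus), using microsomes; on this read-out higher numbers stand for weaker inhibition and lower numbers for stronger inhibition. Compound 1 `CCCCCCCCCCCCCCCC(=O)Nc1cccc2c1OC(C)(C)C2` gives 890 nM. Compound 2 `CCCCCCCCCCCCCCCC(=O)Nc1c(C)cc(C)c2c1OC(C)(C)C2` gives 26 nM. Compound 3 `Cc1cc(C)c(NC(=O)C(C)(C)CCCCCCc2ccccc2)c2c1CC(C)(C)O2` gives 81 nM, which places it second highest of the three numbers, nearer to compound 2 than to compound 1. None of these three differs from another in only one place, so the numbers are read side by side without a single computed step among them.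

Compound 4 `Cc1ccc(OCCCCCCC(C)(C)C(=O)Nc2c(C)cc(C)c3c2OC(C)(C)C3)cc1` has not yet been measured. It differs from compound 3 by 4-methylphenoxy in place of phenyl on a saturated chain carbon, seven bonds along the chain from a carbonyl carbon. No comparable exchange on this core has been measured, so the expectation rests on how compounds 2 and 3 sit together: both carry the same substituted core and both lie far from compound 1. The step of a 1.4-fold lower number from compound 3 to compound 4 (0.13 log units; within the scatter) is expected to be small, within the scatter or at most a modest move toward stronger inhibition. Compound 4 is therefore estimated at 60 nM, with a range from 20 nM to 200 nM.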

Compound 4, half-maximal inhibitory concentration: 50 nM
Compound 4: the middle estimate sits 1.2-fold (0.08 log units) above what was measured, within the range that was stated.
By their numbers in this assay, from the lowest: compounds 2, 4 and 3 (each within the scatter of the next, the first and the last beyond it); then compound 1.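

With compound 3 and compound 4, the study gains its first comparison that differs in one place, and in this assay the exchange of phenyl for 4-methylphenoxy on this saturated chain carbon reads as a 1.6-fold lower number from compound 3 to compound 4 (0.21 log units; within the scatter). This position therefore accepts the larger 4-methylphenoxy group, with its added oxygen and methyl, without any change in inhibition that can be told from the scatter. No measurement here accounts for this tolerance.

Among these compounds, the single exchange brings in the oxygen and the methyl together, so the contribution of each remains open, and plain phenoxy would be needed to separate them. Also open, as far as these compounds go, is whether this position would tolerate groups of a different kind, such as an amine or a carboxylic acid, in place of 4-methylphenoxy.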